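A few compounds are considered here, and "the series" means these few. Any claim that something is new, unique, unknown or untested is made for them only; others in the source may bear on it.

Measured so far:
Compound 1 `COc1ccc(-c2cn3ccnc3c(-c3ccc4ncn(C5CCCCC5)c4c3)n2)cc1` — 56.7%
Compound 2 `O=Cc1ccc(-c2cn3ccnc3c(-c3ccc4ncn(C5CCCCC5)c4c3)n2)cc1` — 20.9%

In a functional assay on EKVX cells (Homo sapiens) for inhibition, read by sulforhodamine B assay, with a stated time of 48 h, tested at 10 uM (a higher number here means more inhibition at the concentration tested (going by the name of the read-out), a lower number less inhibition), compound 1 gives 56.7%, the higher of the two numbers measured. Compound 2 gives 20.9%. Within the data shown here, the only measured step is a number 35.8 percentage points lower from compound 1 to compound 2 (beyond the scatter), which shows that exchanging the group on the outer phenyl ring can shift the read-out by a large amount.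

Compound 3 `Fc1ccccc1-c1cn2ccnc2c(-c2ccc3ncn(C4CCCCC4)c3c2)n1` is not yet measured. It differs from compound 1 by 2-fluorophenyl in place of 4-methoxyphenyl on an aromatic carbon. Among the measured compounds shown here, no measured step exchanges the whole phenyl group in this way, so the single step from compound 1 to compound 2 is the only guide, and it bears on the question only loosely: it shows the read-out is sensitive to this part of the molecule, but the new group is neither methoxy nor formyl.

A moderate decrease is expected, roughly a number 18.7 percentage points lower from compound 1 to compound 3 (beyond the scatter). Compound 3 is estimated at 38%, with a range from 12% to 62%.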

Compound 3, a percentage reported as inhibition, at one concentration (the size of the read-out at that concentration, not a potency): 16%
Compound 3: middle estimate off by 22 percentage points, on the high side, and the stated range covers the measured number.
By their numbers in this assay, from the lowest: compounds 3 and 2 (each within the scatter of the next); then compound 1.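

In this assay the change to 2-fluorophenyl gives a number 40.7 percentage points lower from compound 1 to compound 3 (beyond the scatter) and so adds a second replacement of 4-methoxyphenyl that ends far under compound 1. The two replacement groups themselves cannot be told apart here, with a number 4.9 percentage points lower from compound 2 to compound 3 (within the scatter) and nothing to separate 4-formylphenyl from 2-fluorophenyl in this read-out. Among these three compounds, only the one carrying 4-methoxyphenyl stands apart, although the 2-fluorophenyl group differs from it both in the substituent and in where that substituent sits on the phenyl ring.

Going by these compounds, those two differences remain unseparated, and it is open how a methoxy group at the 2-position of the phenyl ring, or an amine or a carboxylic acid at its 4-position, would read. No measurement shown gives a reason for these differences.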